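Halogenated N-aryl variation on a shared amide core

The compounds below may be only part of what the source reports. "The series", "measured", "known", "first", "only" and "open" are said of these compounds alone.

Measured compounds in a functional assay on A549 cells (Homo sapiens) for antiproliferative activity, read by MTT assay, with a stated time of 72 h; a lower number here means a stronger inhibitor, a higher number a weaker inhibitor:
compound 1 `CNC(=O)c1cc(Oc2ccc(NC(=O)c3cc4cccnc4n(-c4ccc(Br)cc4F)c3=O)cc2)ccn1`, 1420 nM
compound 2 `CNC(=O)c1cc(Oc2ccc(NC(=O)c3cc4cccnc4n(-c4ccc(F)c(Cl)c4)c3=O)cc2)ccn1`, 1560 nM
compound 3 `CCNC(=O)c1cc(Oc2ccc(NC(=O)c3cc4cccnc4n(-c4ccccc4F)c3=O)cc2)ccn1`, 490 nM

Compound 3 has the lowest number of the three, and its gap to compound 1 and to compound 2 lies beyond the scatter. Compound 4 `CCNC(=O)c1cc(Oc2ccc(NC(=O)c3cc4cccnc4n(-c4ccc(C(F)(F)F)cc4Cl)c3=O)cc2)ccn1` differs from compound 3 by 2-chloro-4-(trifluoromethyl)phenyl in place of 2-fluorophenyl on an aromatic nitrogen. Among the compounds with values here, the only single-point step on the same aromatic nitrogen, a 1.1-fold higher number from compound 1 to compound 2 (0.04 log units; within the scatter), shows that exchanging one halogenated aryl for another left this assay unchanged. That step is small and involves smaller groups than the one entering here, so a modest rise in the number for compound 4 in this assay is expected, about a 1.6-fold higher number from compound 3 to compound 4 (0.21 log units; within the scatter). Compound 4 is therefore estimated at 800 nM, with a range of 300 nM to 2500 nM.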

Compound 4, half-maximal inhibitory concentration: 3290 nM
For compound 4 the middle estimate is 4.1-fold (0.61 log units) below the measured one, outside the stated range (above it).
By their numbers in this assay, from the lowest: compound 3; then compounds 1 and 2 (each within the scatter of the next); then compound 4.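

The aryl group on this aromatic nitrogen is not neutral in this assay, where a 6.7-fold higher number from compound 3 to compound 4 (0.83 log units; beyond the scatter) lies beyond the scatter while a 1.1-fold higher number from compound 1 to compound 2 (0.04 log units; within the scatter) stays within it. Not every exchange of one halogenated aryl for another is therefore silent at this position. No available data explain the rise.

The entering group differs from 2-fluorophenyl in both its chlorine and its trifluoromethyl, so the step does not separate them. As far as these compounds go, whether 2-chlorophenyl or 4-(trifluoromethyl)phenyl on the same nitrogen would stand nearer compound 3 or compound 4 remains open.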